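A Methoxycarbonyl Enters the Amine Side Chain

The source may report more compounds than this note shows. Statements on the series, on what has been measured and on what is new or still open speak of the compounds shown alone.

Three compounds share one core and were tested in a functional assay on MCF7 cells (Homo sapiens) for antiproliferative activity; a lower number here means a stronger inhibitor, a higher number a weaker inhibitor. Compound 1 `CC(=O)Oc1ccc(C(=O)Nc2cc3ccc(OCCC4CCCCN4)c(C)c3oc2=O)cc1CC=C(C)C` gives 710 nM. Compound 2 `CC(=O)Oc1ccc(C(=O)Nc2cc3ccc(OCC4CCCNC4)c(C)c3oc2=O)cc1CC=C(C)C` gives 820 nM. Compound 3 `CCNCCCOc1ccc2cc(NC(=O)c3ccc(O)c(CC=C(C)C)c3)c(=O)oc2c1C` gives 980 nM. All three numbers lie within the usual scatter of one another, so compound 3 cannot be set apart from the other two on these data.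

Compound 4 `COC(=O)CNCCCOc1ccc2cc(NC(=O)c3ccc(O)c(CC=C(C)C)c3)c(=O)oc2c1C` differs from compound 3 in one place: methoxycarbonyl in place of methyl on a saturated chain carbon bound to an amine nitrogen. For the measured compounds named here, the only measured step, a 1.2-fold higher number from compound 1 to compound 2 (0.06 log units; within the scatter), concerns the ring on the ether side chain and not the saturated chain carbon bound to the amine nitrogen, so no direct precedent exists for this change. With every known change in this set staying inside the scatter, the estimated step of a 1.3-fold higher number from compound 3 to compound 4 (0.12 log units; within the scatter) is expected to be small, leaning if anything toward a higher number. Compound 4 is therefore estimated at 1300 nM, with a likely range from 500 nM to 3500 nM.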

Compound 4, half-maximal inhibitory concentration: 2820 nM
For compound 4 the middle estimate is 2.2-fold (0.34 log units) below the measured one; measured number inside the range.
By their numbers in this assay, from the lowest: compounds 1, 2 and 3 (each within the scatter of the next); then compound 4.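

In this assay, methoxycarbonyl in place of methyl on a saturated chain carbon bound to an amine nitrogen gives a 2.9-fold higher number from compound 3 to compound 4 (0.46 log units; beyond the scatter), a modest step and the first in this set to lie beyond the scatter. For the compounds shown here, the amine side chain therefore responds to a change at this position, whereas the only earlier step, a 1.2-fold higher number from compound 1 to compound 2 (0.06 log units; within the scatter), concerned the ring on the ether side chain and stayed within the scatter. No measurement at hand accounts for the higher number, so the step remains an observation without an assigned cause.

The compounds shown leave open whether the ester itself or simply the larger substituent matters, and a carboxylic acid, a primary amide or a plain propyl chain at the same place would help separate the two. From the compounds shown here alone, it also remains open whether the same change would give a similar step on the side chains of compound 1 and compound 2.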